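Shortening the piperidine linker on the isoquinoline sulfamate amide

A few compounds are considered here, and "the series" means these few. Any claim that something is new, unique, unknown or untested is made for them only; others in the source may bear on it.

Measured compounds:
compound 1 `CCN(Cc1ccncc1)c1cccc(C(=O)N2CCc3ccc(OS(N)(=O)=O)cc3C2)c1` — 33.3%
compound 2 `CN(CCCN1CCCCC1)c1cccc(C(=O)N2CCc3ccc(OS(N)(=O)=O)cc3C2)c1` — 24.1%
compound 3 `CCN(Cc1cccnc1)c1cccc(C(=O)N2CCc3ccc(OS(N)(=O)=O)cc3C2)c1` — 14.3%

In an assay on HEK293 cells for inhibition of Steryl-sulfatase (Homo sapiens), tested at 0.1 uM (a lower number here means a weaker effect, a higher number a stronger effect of the compound at the concentration tested), compound 3 gives the lowest of the three numbers. Its nearest neighbour is compound 2, with a number 9.8 percentage points lower from compound 2 to compound 3 (within the scatter); the gap to compound 1 is larger, with a number 19 percentage points lower from compound 1 to compound 3 (beyond the scatter). The other measured step, a number 9.2 percentage points lower from compound 1 to compound 2 (within the scatter), likewise stays within the scatter.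

Compound 4 `CN(CCN1CCCCC1)c1cccc(C(=O)N2CCc3ccc(OS(N)(=O)=O)cc3C2)c1` has not yet been measured. It differs from compound 3 as follows: methyl(2-(piperidin-1-yl)ethyl)amino in place of ethyl((pyridin-3-yl)methyl)amino on an aromatic carbon. The entering group is close to the methyl(3-(piperidin-1-yl)propyl)amino of compound 2, so the step that bears most directly on this change is a number 9.8 percentage points lower from compound 2 to compound 3 (within the scatter), which was within the scatter. Compound 4 is therefore expected to land near compound 2, with a step of a number 7.7 percentage points higher from compound 3 to compound 4 (within the scatter) that is expected to be small and upward. The estimate for compound 4 in this assay is 22%, with a range from 10% to 36%.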

Compound 4, a percentage reported as inhibition, at one concentration (the size of the read-out at that concentration, not a potency): 24.5%
Compound 4: middle estimate off by 2.5 percentage points, on the low side; the measured number falls inside the stated range.
By their numbers in this assay, from the lowest: compounds 3, 2, 4 and 1 (each within the scatter of the next, the first and the last beyond it).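

Moving from (piperidin-1-yl)methyl to piperidin-1-yl on the saturated chain makes no readable difference in this assay, with a number 0.4 percentage points higher from compound 2 to compound 4 (within the scatter), so these two chain lengths cannot be told apart at this position. The exchange of ethyl((pyridin-3-yl)methyl)amino for methyl(2-(piperidin-1-yl)ethyl)amino, with the same count of heavy atoms on the same aromatic carbon, gives a number 10.2 percentage points higher from compound 3 to compound 4 (beyond the scatter), while the comparison with the pyridin-4-yl analogue gives a number 8.8 percentage points lower from compound 1 to compound 4 (within the scatter), which places the piperidine side chain clearly above only the pyridin-3-yl compound. No measurement offered here explains these differences.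

Going by these compounds, it remains open whether a morpholine in place of the piperidine, or a butyl linker, would separate from these compounds. A pyridin-2-yl group on the ethylamino side chain also remains untested among the compounds shown.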